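Extending Methyl to Propyl on the Oxadiazole Substituent

This account rests on a few compounds, and the source may have more. Where it says the series, first, only, none or still open, it means among the compounds named here.

Of the compounds shown here, two have so far been tested in an ADME assay on RD cells (Homo sapiens) for cytotoxicity, read by MTT assay, with a stated time of 24 h; a lower number here means that less compound is tolerated, a higher number that more compound is tolerated. Compound 1 `CC(CCOc1ccc(-c2noc(C(F)(F)F)n2)cc1)CCN1CCN(c2ccnc(N)c2)C1=O` gives 48100 nM in this assay, and compound 2 `Cc1nc(-c2ccc(OCCC(C)CCN3CCN(c4ccnc(N)c4)C3=O)cc2)no1` gives 66100 nM. Compound 2 thus carries the higher of the two numbers, but the step of a 1.4-fold higher number from compound 1 to compound 2 (0.14 log units; within the scatter) sits within the scatter, so the two compounds cannot be distinguished on these data. Compound 3 `CCCc1nc(-c2ccc(OCCC(C)CCN3CCN(c4ccnc(N)c4)C3=O)cc2)no1` has not been measured. It differs from compound 2 in one place: ethyl in place of hydrogen on a saturated chain carbon bound to an aromatic carbon, so that the 5-methyl-1,2,4-oxadiazol-3-yl group becomes a 5-propyl-1,2,4-oxadiazol-3-yl group. Within the data shown here, no measured step makes this kind of change; the only step known exchanges trifluoromethyl for methyl on an aromatic carbon and stays within the scatter. In this assay the expected step is therefore a 1.1-fold lower number from compound 2 to compound 3 (0.04 log units; within the scatter), with nothing beyond the scatter. Compound 3 is estimated at 60000 nM, with a range from 30000 nM to 120000 nM.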

Compound 3, half-maximal cytotoxic concentration: > 100000 nM
Compound 3: a limit, no number (the forecaster's own chance of this, stated with the estimate: 15%); at least 1.6-fold (0.22 log units) between middle value and limit.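

Compound 3 stands at a limit of the assay, not at a number: the limit of > 100000 nM in this assay, at which 1 of the 3 values shown sits. Lengthening methyl to propyl gives an at least 1.5-fold higher number from compound 2 to compound 3 (0.17 log units; that floor lies within the scatter), so this change alone does not separate the two compounds, although the true step may be larger than its floor. Among these compounds, exchanging trifluoromethyl for propyl at the same place gives an at least 2.0-fold higher number from compound 1 to compound 3 (0.31 log units; beyond the scatter), the first step in this small set to clear the scatter, which shows that the group held here can shift the number in this assay.

From the compounds shown here alone, how far compound 3 lies past its limit remains unknown, and so does the full size of both steps. Also open, going by these compounds, is whether a longer chain such as butyl, or an amine in place of the propyl group, would keep the number this high.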